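Cytotoxicity of a pyridazinone series: swapping a pyrazole for fluorophenyl

The source may hold more compounds than are shown below. What is called first, only, known or untested is meant among the compounds shown, and "the series" means these compounds.

Of the compounds shown here, three have been tested in an ADME assay on Huh-7 cells (Homo sapiens) for cytotoxicity, read by MTT assay, with a stated time of 48 h; on this read-out higher numbers stand for lower toxicity in this test and lower numbers for higher toxicity in this test. Compound 1 `Nc1ccc(CN2N=C(c3ccc(F)cc3)C3C=CC=CC3C2=O)cc1` reaches only the limit of the test, giving > 80000 nM, so no number is known for it; this limit is the limit of > 80000 nM in this assay, at which 1 of the 3 values shown sits. Compound 2 `CCCCOC(=O)Nc1ccc(CN2N=C(c3ccc(F)cc3)C3C=CC=CC3C2=O)cc1` gives 19500 nM in this assay, and compound 3 `CN(C)CCCCOC(=O)Nc1ccc(Cn2nc(-c3cnn(C)c3)c3ccccc3c2=O)cc1` gives 55900 nM, the highest of the two numbers shown, with compound 2 the nearest to it. Going by the values given here, the single measured step, an at least 4.1-fold lower number from compound 1 to compound 2 (0.61 log units; beyond the scatter), concerns a different change from the one considered here. Compound 4 `CN(C)CCCCOC(=O)Nc1ccc(Cn2nc(-c3cccc(F)c3)c3ccccc3c2=O)cc1` differs from compound 3 in one place: 3-fluorophenyl in place of 1-methyl-1H-pyrazol-4-yl on an aromatic carbon. Among the compounds with values here, no measured step in this assay bears on this replacement, and compound 2, which carries a fluorophenyl, also differs from compound 3 in its core and its chain, so it offers no clean comparison. The expectation for compound 4 is therefore a step no larger than the scatter, at most a slight fall, expressed as a 1.4-fold lower number from compound 3 to compound 4 (0.15 log units; within the scatter). Compound 4 is estimated at 40000 nM, expected to lie between 15000 nM and 90000 nM.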

Compound 4, half-maximal cytotoxic concentration: 37400 nM
Beside the measured number, compound 4's estimate is 1.1-fold (0.03 log units) above it; the range from low to high includes it.
By their numbers in this assay, from the lowest: compounds 2, 4 and 3 (each within the scatter of the next, the first and the last beyond it). At a limit, above all of these: compound 1.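

Exchanging 1-methyl-1H-pyrazol-4-yl for 3-fluorophenyl on the aromatic carbon next to the ring nitrogen gives a 1.5-fold lower number from compound 3 to compound 4 (0.17 log units; within the scatter) in this assay, so this test does not separate the two groups at this position. The group that leaves has 2 hydrogen-bond acceptors and the one that enters has 0, yet in this pair that difference in count comes with no step beyond the scatter. Nothing measured here gives a reason for this result.

The compounds shown leave open whether an unsubstituted phenyl, or a phenyl carrying a carboxylic acid or an amine, would also stay within the scatter of compound 3. They also leave open whether the same exchange would give a similar result on the core of compound 2, with its butoxycarbonyl group.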